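Lengthening the chloroalkyl chain of an anilide

The source may hold more compounds than are shown below. What is called first, only, known or untested is meant among the compounds shown, and "the series" means these compounds.

Compound 1 `O=C(NCCCCl)Nc1ccc(I)cc1`: in a functional assay on M21 cells (Homo sapiens) for antiproliferative activity, with a stated time of 48 h (a lower number here means a stronger inhibitor, a higher number a weaker inhibitor), compound 1 gives > 100000 nM, which is a limit of the assay and not a number.
Compound 2 `O=C(CCl)Nc1ccc(I)cc1`: compound 2 gives 5100 nM.
Compound 3 `CC(C)(C)c1ccc(NC(=O)CCl)cc1`: compound 3 gives 5400 nM.

Of the two numbers shown, compound 2 holds the lower, but compound 3 sits within the scatter of it, so the two cannot be told apart. Two measured steps exist. Within the data shown here, the first is an at least 19-fold lower number from compound 1 to compound 2 (1.29 log units; beyond the scatter); the only firm knowledge about compound 1 is the limit of > 100000 nM in this assay, at which 1 of the 3 values shown sits. The second is a 1.1-fold higher number from compound 2 to compound 3 (0.02 log units; within the scatter), which shows that swapping the group on the aromatic ring left the read-out essentially unchanged.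

Compound 4 `O=C(CCCl)Nc1ccc(I)cc1` differs from compound 2 in one place: chloromethyl in place of chloro on a saturated chain carbon bound to a carbonyl carbon. This change alters the chain between the chlorine and the carbonyl, the same region that was touched in the large step from compound 1 to compound 2, whereas the small step to compound 3 touched only the ring. The step to compound 4 is therefore expected to matter, and to move the number upward, though by less than the full gap to compound 1.

Compound 4 is estimated to give 30000 nM, within 6000 nM to 100000 nM, meaning an expected step of a 5.9-fold higher number from compound 2 to compound 4 (0.77 log units; beyond the scatter).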

Compound 4, half-maximal inhibitory concentration: 20000 nM
Compound 4: middle estimate off by 1.5-fold (0.18 log units), on the high side; the measured number falls inside the stated range.
By their numbers in this assay, from the lowest: compounds 2 and 3 (each within the scatter of the next); then compound 4. At a limit, above all of these: compound 1.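

In this assay, going from chloromethyl to 2-chloroethyl on the carbonyl carbon gives a 3.9-fold higher number from compound 2 to compound 4 (0.59 log units; beyond the scatter), so this chain responds to even a small extension, whereas the earlier swap on the ring, from iodo to tert-butyl, stayed within the scatter. With 2-chloroethyl in place of (3-chloropropyl)amino on the carbonyl carbon, the step is an at least 5.0-fold lower number from compound 1 to compound 4 (0.69 log units; beyond the scatter), which shows that a measurable number returns once that amino-containing group is gone, even with the longer chain in place. Compound 1 stands at a limit of the assay and not at a number, so this second step gives only a bound on the size of the change: the limit of > 100000 nM in this assay, at which 1 of the 4 values shown sits.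

The compounds shown leave open whether the number keeps rising with a longer chain, such as 3-chloropropyl directly on the carbonyl carbon, and whether the chlorine itself is needed, since none of them carries a hydroxyl or an amine at the end of the chain instead. They also leave open whether 2-chloroethyl has the same effect with tert-butyl on the ring as it has with iodo.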